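The source may report more compounds than this note shows. Statements on the series, on what has been measured and on what is new or still open speak of the compounds shown alone.

Measured so far in a functional assay on cells (Homo sapiens) for antiproliferative activity, read by MTT assay, with a stated time of 48 h; a higher number here means a weaker inhibitor, a lower number a stronger inhibitor:
compound 1 `Cn1c(N)c(-c2nc3ccccc3[nH]2)c2nc(C#N)c(C#N)nc21`: > 50000 nM
compound 2 `CCCCn1c(N)c(-c2nc3ccccc3[nH]2)c2nc(C#N)c(C#N)nc21`: > 50000 nM
compound 3 `N#Cc1nc2c(-c3nc4ccccc4[nH]3)c(N)n(CCCO)c2nc1C#N`: > 50000 nM

Each of these entries is a limit of the assay and not a number. Compound 1 therefore has no exact place on the scale, only its limit of > 50000 nM. It shares that position with the other two compounds: the limit of > 50000 nM in this assay, at which 3 of the 3 values shown sit.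

Compound 4 `CN(C)CCCCn1c(-c2c(N)n(C)c3nc(C#N)c(C#N)nc23)nc2ccccc21` keeps the core of compound 1 and changes it in one place: 4-(dimethylamino)butyl in place of hydrogen on an aromatic nitrogen. In words, 4-(dimethylamino)butyl stands in place of hydrogen on an aromatic nitrogen. Among the compounds with values here, three measured steps bear on this only loosely: a step that the two limits leave unreadable from compound 1 to compound 2, a step that the two limits leave unreadable from compound 1 to compound 3 and a step that the two limits leave unreadable from compound 2 to compound 3. All three alter a saturated chain rather than the hydrogen replaced in compound 4, and none gives a size to carry over. In this assay, the expected change is an at least 2.0-fold lower number from compound 1 to compound 4 (0.30 log units; that floor lies within the scatter), a rough estimate towards stronger inhibition, and the result may well remain a limit. For compound 4 the estimate is 25000 nM, with an expected range from 5000 nM to 60000 nM.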

Compound 4, half-maximal inhibitory concentration: 6480 nM
Beside the measured number, compound 4's estimate is 3.9-fold (0.59 log units) above it, within the range that was stated.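

In this assay, within the data shown here, 4-(dimethylamino)butyl in place of hydrogen on an aromatic nitrogen gives the only readable step, an at least 7.7-fold lower number from compound 1 to compound 4 (0.88 log units; beyond the scatter), whereas the steps among the earlier compounds cannot be read. Compound 1 sits at a limit of the assay and not at a number, so this step gives a floor and not a full size. Changing this position thus moves compound 4 off the limit that holds the other compounds: the limit of > 50000 nM in this assay, at which 3 of the 4 values shown sit.

As far as these compounds go, it remains open whether a plain butyl chain, a shorter chain ending in the same dimethylamino group, or a morpholine at the chain end would give a similar step on this aromatic nitrogen. From the compounds shown here alone, it is also open whether 4-(dimethylamino)butyl would give such a step on the core of compound 2 or compound 3.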